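A Quiet Series and One More Exchange

A few compounds are considered here, and "the series" means these few. Any claim that something is new, unique, unknown or untested is made for them only; others in the source may bear on it.

Three compounds sharing one core were tested in a functional assay on NCI-H460 cells (Homo sapiens) for cytotoxicity, read by MTT assay; a lower number here means a stronger inhibitor, a higher number a weaker inhibitor. Compound 1 `Cc1cccc(Nc2nc(C)c(C(=O)/C=C/c3ccc(Cl)cc3)s2)c1` reached only the limit of the measurement, > 25000 nM, so no number is known for it. Compound 2 `Cc1cccc(Nc2nc(C)c(C(=O)/C=C/c3ccccc3Cl)s2)c1` differs from compound 1 by a 2-chlorophenyl in place of a 4-chlorophenyl on a double-bonded chain carbon bound to a double-bonded chain carbon. Compound 2 also stopped at a limit, > 25000 nM. Compound 3 `COc1cc(/C=C/C(=O)c2sc(Nc3ccc(Cl)c(Cl)c3)nc2C)cc(OC)c1OC` gave a limit as well, > 25000 nM. The step that the two limits leave unreadable from compound 1 to compound 2 is therefore unreadable, and compound 1 stands at the limit of > 25000 nM in this assay, at which 3 of the 3 values shown sit, with every other measured value.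

The unmeasured compound 4 `Cc1nc(Nc2ccc(Cl)c(Cl)c2)sc1C(=O)/C=C/c1ccc(Cl)cc1` differs from compound 1 by 3,4-dichlorophenyl in place of 3-methylphenyl on a nitrogen on an aromatic ring. Among the measured compounds shown here, no measured step touches this nitrogen, so nothing shows how large a change there might be in this assay. Compound 3 does carry the same 3,4-dichlorophenyl on that nitrogen, paired with a different chain end, and its value sits at the limit like compound 1. With that in mind, compound 4 is expected to return a limit again in this assay, so that the step that the limit leaves unreadable from compound 1 to compound 4 is estimated to stay within the scatter. The estimate for compound 4 is 35000 nM, between 15000 nM and 80000 nM.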

Compound 4, half-maximal inhibitory concentration: > 25000 nM
Compound 4 was reported as a limit; the forecaster's own chance of this, stated with the estimate: 85%; the middle value lies beyond the limit too.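

In this assay compound 4 gives > 25000 nM, which is a limit and not a number. Compound 1 also stopped at a limit, so the step between compound 1 and compound 4 cannot be read, and the series remains at one value: the limit of > 25000 nM in this assay, at which 4 of the 4 values shown sit.

The compounds shown leave open whether any change to the shared core would give a measurable value in this assay.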